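Thiophen-2-yl in place of thiophen-3-yl: outlook for compound 4

A few compounds are considered here, and "the series" means these few. Any claim that something is new, unique, unknown or untested is made for them only; others in the source may bear on it.

Compound 1 `CC1=C(C(=O)OC(C(F)(F)F)C(F)(F)F)C(c2ccsc2)NC(=O)N1` stands highest of the two single numbers in an assay on HeLa cells for displacement of a labelled ligand from adenosine receptor A3 (Homo sapiens), read by radioligand binding, with a stated time of 180 min, tested at 1 uM (on this read-out lower numbers stand for less inhibition and higher numbers for more inhibition at the one concentration tested (going by the name of the read-out)), where compound 1 gives 8%; compound 3 `CC1=C(C(=O)OCC(F)(F)F)C(c2ccsc2)NC(=O)N1` gives 1%, and compound 2 `CC1=C(C(=O)OC(C)C(F)(F)F)C(c2cccs2)NC(=O)N1` has two entries, 3%; 3% (2 entries). Going by the values given here, the only measured step, a number 7 percentage points lower from compound 1 to compound 3 (within the scatter), lies within the scatter. Compound 4 `CC1=C(C(=O)OC(C(F)(F)F)C(F)(F)F)C(c2cccs2)NC(=O)N1` differs from compound 1 by thiophen-2-yl in place of thiophen-3-yl on a saturated ring carbon. Among the compounds with values here, no measured step bears directly on this change; compound 2, which also carries thiophen-2-yl, sits low as well, and every value lies near the bottom of the read-out. No step beyond the scatter is therefore expected in this assay for compound 4. Compound 4 is estimated at 5%, with a range from -5% to 15%, which means an expected step of a number 3 percentage points lower from compound 1 to compound 4 (within the scatter).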

Compound 4, a percentage reported as inhibition, at one concentration (the size of the read-out at that concentration, not a potency): 1%
For compound 4 the middle estimate is 4 percentage points above the measured one, and the stated range covers the measured number.
By their numbers in this assay, from the lowest: compounds 3, 4 and 1 (each within the scatter of the next).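

In this assay, going by these compounds alone, thiophen-2-yl in place of thiophen-3-yl on the saturated ring carbon gives a number 7 percentage points lower from compound 1 to compound 4 (within the scatter) as the only measured step at this position. With the rest of compound 1 held fixed, the two thiophene attachments are not told apart at this one concentration. No measurement at hand bears on the reason for this result.

Going by these compounds, whether the thiophene attachment matters in a compound with higher inhibition remains open, as all numbers here sit near the bottom of the read-out. Also open, on these data alone, is how a phenyl ring or an amine at this ring carbon would read.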